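This account rests on a few compounds, and the source may have more. Where it says the series, first, only, none or still open, it means among the compounds named here.

Compound 1, with the structure `NC(=S)Nc1cccc(OCCCCCOc2ccccc2)c1`, sits at the edge of what an ADME assay on Ava5 cells (Homo sapiens) for cytotoxicity (on this read-out higher numbers stand for lower toxicity in this test and lower numbers for higher toxicity in this test), can report. In this assay compound 1 gives > 50000 nM, which is a limit of the assay rather than a number. Two measured neighbours differ from compound 1 in one place. Compound 2, with the structure `NC(=S)Nc1cccc(OCCCCCOc2cccc(-c3ccccc3)c2)c1`, gives 13000 nM in this assay. Compound 3, with the structure `NC(=S)Nc1cccc(OCCCCCOc2ccc(-n3cccc3)cc2)c1`, gives > 50000 nM in this assay, again a limit. The step of an at least 3.8-fold lower number from compound 1 to compound 2 (0.58 log units; beyond the scatter) is the only one of a readable size; the step that the two limits leave unreadable from compound 1 to compound 3 cannot be sized, because the limit of > 50000 nM in this assay, at which 2 of the 3 values shown sit, holds both ends of it.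

Compound 4, with the structure `NC(=S)Nc1cccc(OCCCCCOc2cccnc2)c1`, is not yet measured in this assay. It differs from compound 1 in that (pyridin-3-yl in place of phenyl on an oxygen on a saturated carbon). Neither measured step matches this change: both add a ring to an aromatic carbon of the shared core, whereas here a ring is swapped for another of the same size at the far end of the chain. No step beyond the scatter is therefore expected in this assay, so the expected step of a number no higher from compound 1 to compound 4 (the limit leaves the size open) is small. Compound 4 is expected to give about 50000 nM, within a range from 20000 nM to 100000 nM, most likely reported again as a limit.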

Compound 4, half-maximal cytotoxic concentration: > 50000 nM
Compound 4: only a limit was reported; the forecaster's own chance of this, stated with the estimate: 70%; the middle value sits exactly at the limit.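

Compound 4 stays at a limit of this assay, just as compound 1 does, so no size can be read for the step between them: the limit of > 50000 nM in this assay, at which 3 of the 4 values shown sit.

The compounds shown leave open whether pyridin-3-yl in place of phenyl changes the read-out in this assay at all, and in which direction any such change would run.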